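Compound 3 to compound 4: extending the selenium-bearing chain

The compounds below may be only part of what the source reports. "The series", "measured", "known", "first", "only" and "open" are said of these compounds alone.

Values in a functional assay on HepG2 cells (Homo sapiens) for antiproliferative activity, read by MTT assay, with a stated time of 48 h; a higher number here means a weaker inhibitor, a lower number a stronger inhibitor:
- compound 1 `COc1ccc(N(C)c2ccnc(Cl)n2)cc1F`: 844 nM
- compound 2 `COc1ccc(N(C)c2ccnc(Cl)n2)cc1OCCBr`: 7720 nM
- compound 3 `COc1ccc(N(C)c2ccnc(Cl)n2)cc1OCC[Se]C#N`: 1670 nM

Compound 3 sits level with compound 1, a 2.0-fold higher number from compound 1 to compound 3 (0.30 log units; within the scatter), and clear of compound 2, a 4.6-fold lower number from compound 2 to compound 3 (0.66 log units; beyond the scatter). Compound 4 `COc1ccc(N(C)c2ccnc(Cl)n2)cc1OCCC[Se]C#N` is not yet measured and differs from compound 3 by a group of 4 heavy atoms (2 carbon, 1 nitrogen, 1 selenium; no ring) in place of a group of 3 heavy atoms (1 carbon, 1 nitrogen, 1 selenium; no ring), on a saturated chain carbon, two bonds along the chain from an oxygen on an aromatic ring. Among the compounds with values here, no measured step makes this change. The closest is the replacement at the same chain carbon, a 4.6-fold lower number from compound 2 to compound 3 (0.66 log units; beyond the scatter), which was modest, while a 9.1-fold higher number from compound 1 to compound 2 (0.96 log units; beyond the scatter) shows that this side of the series can move beyond the scatter. In this assay a small change or none beyond the scatter is therefore expected. The expected step is a 1.0-fold higher number from compound 3 to compound 4 (0.01 log units; within the scatter). For compound 4 the estimate is 1700 nM, with an expected range of 700 nM to 4200 nM.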

Compound 4, half-maximal inhibitory concentration: 5150 nM
The estimate for compound 4 lay 3.0-fold (0.48 log units) below the measured number; the measured number lies above the stated range.
By their numbers in this assay, from the lowest: compounds 1 and 3 (each within the scatter of the next); then compounds 4 and 2 (each within the scatter of the next).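

Chain length at this position matters on its own, with the selenium-bearing end kept: a 3.1-fold higher number from compound 3 to compound 4 (0.49 log units; beyond the scatter). The separation from the bromo compound seen with compound 3 does not survive the longer selenium-bearing group, a 1.5-fold lower number from compound 2 to compound 4 (0.18 log units; within the scatter), and unlike compound 3, the new compound stands clear of the fluoro compound, a 6.1-fold higher number from compound 1 to compound 4 (0.79 log units; beyond the scatter). Nothing available explains this chain-length effect. As far as these compounds go, whether a longer chain moves the number further remains open, as does whether an amine at the chain end would behave like the selenium-bearing group or the bromine.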